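The source may hold more compounds than are shown below. What is called first, only, known or untested is meant among the compounds shown, and "the series" means these compounds.

Measured so far in a functional assay on MCF7 cells (Homo sapiens) for inhibition, read by MTT assay, with a stated time of 72 h; a higher number here means a weaker inhibitor, a lower number a stronger inhibitor:
- compound 1 (`COc1cc(OC)c(OC)cc1/C=C/C(=O)c1ccccc1`) gives > 150000 nM as a limit
- compound 2 (`COc1cc(OC)c(OC)cc1/C=C/C(=O)c1ccc(-c2c[nH]cn2)cc1`) gives > 150000 nM as a limit
- compound 3 (`COc1cc(OC)c(OC)cc1/C=C/C(=O)c1cccc(C(F)(F)F)c1`) gives > 150000 nM as a limit

Compound 1 stands only at a limit (> 150000 nM) and has no number. The whole set sits there too (the limit of > 150000 nM in this assay, at which 3 of the 3 values shown sit).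

Compound 4 (`COc1cc(OC)c(OC)cc1/C=C/C(=O)c1cc(O)ccc1O`) is not yet measured. It carries 2,5-dihydroxyphenyl in place of phenyl on a carbonyl carbon.

Going by the values given here, two measured steps bear on this change (a step that the two limits leave unreadable from compound 1 to compound 2) (a step that the two limits leave unreadable from compound 1 to compound 3). Both are substitutions on the phenyl of compound 1, and neither gives a size, so the expectation in this assay rests on little. Replacing the phenyl with 2,5-dihydroxyphenyl is a different change from either of them. A move toward a stronger inhibitor is expected, with low confidence (an at least 3.7-fold lower number from compound 1 to compound 4 (0.57 log units; beyond the scatter)). Staying at the same limit remains a real possibility. For compound 4 the expected value is 40000 nM in the estimated range 8000 nM to 150000 nM in this assay once measured.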

Compound 4, half-maximal inhibitory concentration: > 150000 nM
Compound 4: no number, only a limit; the forecaster's own chance of this, stated with the estimate: 35%; middle value at least 3.7-fold (0.57 log units) away from the limit.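

In this assay compound 4 gives > 150000 nM, which is a limit and not a number. Its step from compound 1 therefore cannot be read, nor can those to compound 2 and compound 3. The compounds shown leave open whether any of these changes to the phenyl alters inhibition, as all values share one limit: the limit of > 150000 nM in this assay, at which 4 of the 4 values shown sit.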